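Morpholin-4-yl for Thiomorpholin-4-yl on a Thiocarbonyl Carbon

This account rests on a few compounds, and the source may have more. Where it says the series, first, only, none or still open, it means among the compounds named here.

Three compounds were measured in a functional assay on A-375 cells (Homo sapiens) for cytotoxicity, read by MTT assay, with a stated time of 72 h, tested at 3 uM; on this read-out lower numbers stand for less inhibition of growth and higher numbers for more inhibition of growth at the one concentration tested. Compound 1 `Cc1ccnc(/C(N)=N/NC(=S)N2CCOCC2)c1` gives 66.6%, compound 3 `Cc1ccnc(/C(N)=N/NC(=S)N2CCSCC2)c1` gives 67.2%, and compound 2 `Cc1cccc(/C(N)=N/NC(=S)N2CCSCC2)n1` gives 60.1%; all three values lie within the scatter of one another. The change from compound 3 to compound 1 is morpholin-4-yl in place of thiomorpholin-4-yl on a thiocarbonyl carbon, and it made a step of a number 0.6 percentage points lower from compound 3 to compound 1 (within the scatter). Compound 4 `Cc1cccc(/C(N)=N/NC(=S)N2CCOCC2)n1` is not yet measured; it differs from compound 2 by morpholin-4-yl in place of thiomorpholin-4-yl on a thiocarbonyl carbon, the same change at the same place. The difference between the cores of compound 2 and compound 3 is not broken down here. Compound 4 is expected to give 59.5%, between 49% and 70%, because the same change earlier gave a number 0.6 percentage points lower from compound 3 to compound 1 (within the scatter). That amounts to an expected step of a number 0.6 percentage points lower from compound 2 to compound 4 (within the scatter) in this assay, essentially no change.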

Compound 4, percent growth inhibition at one concentration: 34.7%
Compound 4: the middle estimate sits 24.8 percentage points above what was measured; measured number outside the range, below it.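

Morpholin-4-yl in place of thiomorpholin-4-yl on a thiocarbonyl carbon gave a number 25.4 percentage points lower from compound 2 to compound 4 (beyond the scatter) in this assay. The effect of this change therefore did not carry over unchanged from one core to the other: the same change on two cores in this assay, a number 0.6 percentage points lower (within the scatter) from compound 3 to compound 1 and a number 25.4 percentage points lower (beyond the scatter) from compound 2 to compound 4, 24.8 percentage points apart, beyond the scatter of two such steps This shows that, for these two pairs, the result of the change depends on the core that carries it, but it does not show which feature of the cores matters or what the change would do on a third core.

Still open, as far as these compounds go, is how a piperidin-1-yl ring or an open-chain dimethylamino group on the same thiocarbonyl carbon would behave on each core. Also open, from the compounds shown here alone, is whether the gap between the two cores would remain with such groups.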